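The compounds below may be only part of what the source reports. "The series", "measured", "known", "first", "only" and "open" are said of these compounds alone.

Working notes on the series. Compound 1 `CC(C)(C)c1ccc(C(=O)N2CCC3(CC2)C(=O)N(CC(=O)NCCC(=O)O)CN3c2ccccc2)cc1` is the carboxy-terminated member; in an assay on HEK293 cells for displacement of a labelled ligand from NPC1-like intracellular cholesterol transporter 1 (Homo sapiens) (on this read-out higher numbers stand for weaker inhibition and lower numbers for stronger inhibition), compound 1 gives 11400 nM. Compound 2 `CC(C)(C)c1ccc(C(=O)N2CCC3(CC2)C(=O)N(CC(=O)NCCN)CN3c2ccccc2)cc1` carries the amino group at the same place, and in this assay compound 2 gives 7000 nM. Going by the values given here, on the two numbers so far compound 2 holds the lower one, but the step of a 1.6-fold lower number from compound 1 to compound 2 (0.21 log units; within the scatter) is within the scatter, so the two compounds cannot be told apart on this read-out.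

The next member is compound 3 `CC(C)(C)OC(=O)NCCCCCNC(=O)CN1CN(c2ccccc2)C2(CCN(C(=O)c3ccc(C(C)(C)C)cc3)CC2)C1=O`, which differs from compound 2 as follows: 3-((tert-butoxycarbonyl)amino)propyl in place of amino on a saturated chain carbon, two bonds along the chain from an amide-type nitrogen. Among the compounds with values here, the only measured step, a 1.6-fold lower number from compound 1 to compound 2 (0.21 log units; within the scatter), concerns a swap of a small polar end at the same place, not the lengthening and capping that compound 3 brings; it was small and offers no direction for the present change. Nothing measured bears on the entering group itself, so no step beyond the scatter is expected in this assay, with a wide margin on either side. Compound 3 is therefore estimated at 7000 nM (range 2500 nM to 20000 nM), which means an expected step of no change at the digits printed from compound 2 to compound 3 (within the scatter).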

Compound 3, half-maximal inhibitory concentration: 13700 nM
Compound 3: middle estimate off by 2.0-fold (0.29 log units), on the low side; the measured number falls inside the stated range.
By their numbers in this assay, from the lowest: compounds 2, 1 and 3 (each within the scatter of the next).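

In this assay, the exchange of amino for 3-((tert-butoxycarbonyl)amino)propyl, with 11 heavy atoms entering for 1 on a saturated chain carbon, two bonds along the chain from an amide-type nitrogen, gives a 2.0-fold higher number from compound 2 to compound 3 (0.29 log units; within the scatter) and stays within the scatter. The comparison with the carboxy end gives a 1.2-fold higher number from compound 1 to compound 3 (0.08 log units; within the scatter) and is also within the scatter, so a far larger capped end joins the two small ends without being told apart from them on this read-out. Nothing measured here offers an explanation for this result.

Compound 3 differs from compound 2 in both chain length and the tert-butoxycarbonyl cap, so the shown compounds leave the two contributions unseparated; the free primary amine on the same longer chain, or a carboxylic acid on that chain, would bear on this. Also open, from the compounds shown here alone, is whether any group at this place, such as a phenyl ring or a tertiary amine at the chain end, moves the number beyond the scatter.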